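A few compounds are considered here, and "the series" means these few. Any claim that something is new, unique, unknown or untested is made for them only; others in the source may bear on it.

Working notes on the series. Within the data shown here, compound 1 `CCOc1ccc(NC(=O)Nc2cccc(CNc3nccnc3Cl)c2)cc1` gives 7050 nM in a functional assay on HepG2 cells (Homo sapiens) for antiproliferative activity, read by MTT assay, with a stated time of 48 h (on this read-out lower numbers stand for stronger inhibition and higher numbers for weaker inhibition), the lowest of the three numbers so far; compound 2 `O=C(Nc1cccc(Cl)c1)Nc1cccc(CNc2nccnc2Cl)c1` gives 9140 nM and compound 3 `CS(=O)(=O)c1ccc(NC(=O)Nc2cccc(CNc3nccnc3Cl)c2)cc1` gives 15100 nM. The next member, compound 4 `Cc1ccc(NC(=O)Nc2cccc(CNc3nccnc3Cl)c2)cc1`, differs from compound 1 by methyl in place of ethoxy on an aromatic carbon. The step that bears most directly on it is the exchange at the same aromatic carbon, a 2.1-fold higher number from compound 1 to compound 3 (0.33 log units; beyond the scatter), a modest change; the exchange of the whole aryl group, a 1.3-fold higher number from compound 1 to compound 2 (0.11 log units; within the scatter), stayed within the scatter. Both changes at this end of the core moved this assay only slightly, so a small step is expected here as well, a 1.2-fold higher number from compound 1 to compound 4 (0.08 log units; within the scatter), if any at all. Compound 4 is therefore estimated at 8500 nM in this assay, with a range of 4200 nM to 17000 nM.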

Compound 4, half-maximal inhibitory concentration: 11500 nM
Compound 4: the middle estimate sits 1.4-fold (0.13 log units) below what was measured; low and high end bracket the measured number.
By their numbers in this assay, from the lowest: compounds 1, 2, 4 and 3 (each within the scatter of the next, the first and the last beyond it).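

The exchange of ethoxy for methyl on this aromatic carbon, a 1.6-fold higher number from compound 1 to compound 4 (0.21 log units; within the scatter), adds a second small step at this position in this assay. With a 1.3-fold lower number from compound 3 to compound 4 (0.12 log units; within the scatter) and a 1.3-fold higher number from compound 2 to compound 4 (0.10 log units; within the scatter) also inside the scatter, the methyl compound cannot be told apart from any of the other three, and only the exchange for methylsulfonyl leaves the scatter. Nothing at hand explains the size of these steps.

From the compounds shown here alone, whether an amine, a carboxylic acid or a chain longer than ethoxy on this carbon would give a larger step stays open. Also open, going by these compounds, is whether these small steps would hold with changes elsewhere on the shared core.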